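The compounds below may be only part of what the source reports. "The series", "measured", "known", "first", "only" and "open" are said of these compounds alone.

Measured in a physicochemical assay for permeability, using PAMPA; on this read-out lower numbers stand for lower permeability and higher numbers for higher permeability:
- Compound 1 `COCCOc1cc2oc(=O)n(CCC(=O)O)c2cc1Cl`: < 3 nm/s, a limit
- Compound 2 `O=C(O)CCn1c(=O)oc2cc(OCC3CCC3)c(Cl)cc21`: 12 nm/s
- Compound 3 `CCc1cc2oc(=O)n(CCC(=O)O)c2cc1Cl`: < 10 nm/s, a limit

Compound 3 gives only a limit, < 10 nm/s. Compound 1 also gives only a limit, < 3 nm/s. Compound 2 is the only one of the three with a number, 12 nm/s.

The next compound, compound 4 `O=C(O)CCn1c(=O)oc2cc(Cl)c(Cl)cc21`, differs from compound 3 in one group: chloro in place of ethyl on an aromatic carbon. This puts chloro in place of ethyl on an aromatic carbon, ortho to a chloro group.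

Among the compounds with values here, no measured step makes this exchange. The closest is an at least 1.2-fold lower number from compound 2 to compound 3 (0.07 log units; that floor lies within the scatter), where ethyl replaces cyclobutylmethoxy on an aromatic carbon, but it gives only a floor within the scatter. The step that the two limits leave unreadable from compound 1 to compound 3 changes the same aromatic carbon, but its size cannot be read. Within the data shown here, the only step beyond the scatter is an at least 4.0-fold higher number from compound 1 to compound 2 (0.60 log units; beyond the scatter), and it concerns a saturated chain carbon rather than the ethyl group.

No step beyond the scatter is therefore expected in this assay, and neither direction is favoured. The estimated change is a step that the limit leaves unreadable from compound 3 to compound 4. A report of a limit rather than a number is also expected to be more likely than not. For compound 4 the estimate is 6 nm/s, with an expected range from 2 nm/s to 15 nm/s.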

Compound 4, apparent permeability: 24 nm/s
The estimate for compound 4 lay 4.0-fold (0.60 log units) below the measured number; measured number above the stated range.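

On the aromatic carbon ortho to a chloro group, chloro in place of ethyl gives the first step from ethyl at this position that can be read as beyond the scatter in this assay: an at least 2.4-fold higher number from compound 3 to compound 4 (0.38 log units; beyond the scatter). At the same carbon, chloro in place of 2-methoxyethoxy gives an at least 8.0-fold higher number from compound 1 to compound 4 (0.90 log units; beyond the scatter), whereas chloro in place of cyclobutylmethoxy gives a 2.0-fold higher number from compound 2 to compound 4 (0.30 log units; within the scatter), which stays within the scatter, so the outcome of placing chloro here depends on the group it replaces. Neither of the two floors gives an upper size, and the one starting from ethyl rests on a limit: the limit of < 10 nm/s in this assay, at which 1 of the 4 values shown sits.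

Fluoro, bromo or a nitrile on this aromatic carbon would show whether the number of compound 4 is particular to chloro or is shared by other small groups, and an amine there would test a group with hydrogen-bond donors at the same position. Going by these compounds, it also remains open whether the step from ethyl to chloro holds without the chloro group already on the ring, or with an ester or an amide in place of the carboxylic acid on the chain.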